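The compounds below may be only part of what the source reports. "The series", "measured", "known", "first", "only" and "open" are said of these compounds alone.

Compound 2 `COc1ccc(-c2cnc(NC(=O)c3cnco3)n2C)cc1` carries a 1,3-oxazol-5-yl group on its carbonyl carbon. In a toxicity assay on THP-1 cells (Homo sapiens) for inhibition (a lower number here means that less compound is tolerated, a higher number that more compound is tolerated), compound 2 gives > 100000 nM, which is a limit of the assay rather than a measured number. Compound 1 `COc1ccc(-c2cnc(NC(=O)c3ccco3)n2C)cc1` differs from compound 2 only in a furan-2-yl group in that place. In this assay compound 1 gives > 100000 nM, again a limit of the assay and not a number. The step that the two limits leave unreadable from compound 1 to compound 2 therefore cannot be read in size, since both compounds sit at the limit of > 100000 nM in this assay, at which 2 of the 2 values shown sit. Compound 3 `COc1ccc(-c2cnc(NC(=O)c3ccccc3C#N)n2C)cc1` is the compound still to be measured. It differs from compound 2 by 2-cyanophenyl in place of 1,3-oxazol-5-yl on a carbonyl carbon. Within the data shown here, no measured step bears directly on this change: the only measured step, from compound 1 to compound 2, stays unreadable. With both measured compounds at the limit, no direction can be taken from the numbers, and the most plausible expectation is that compound 3 is tolerated much as compound 2 is. The expected step of a number no higher from compound 2 to compound 3 (the limit leaves the size open) is therefore none beyond the scatter. For compound 3 the estimate in this assay is 100000 nM, with a range from 30000 nM to 300000 nM.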

Compound 3, half-maximal cytotoxic concentration: > 100000 nM
Compound 3 gave a limit, no number; the forecaster's own chance of this, stated with the estimate: 70%; the middle value sits exactly at the limit.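

In this assay compound 3 gives > 100000 nM, which is a limit of the assay and not a number. No step among compound 1, compound 2 and compound 3 can be read in size, because all three stand at the same point: the limit of > 100000 nM in this assay, at which 3 of the 3 values shown sit.

The compounds shown leave open whether furan-2-yl, 1,3-oxazol-5-yl and 2-cyanophenyl on the carbonyl carbon differ at all in how well they are tolerated.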